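The source may report more compounds than this note shows. Statements on the series, on what has been measured and on what is new or still open speak of the compounds shown alone.

For the measured compounds named here, compound 3 `Cc1c(Cc2cccnc2)cc2c(c1/C=C/CCCC(=O)O)CCC(NS(=O)(=O)c1ccc(Cl)cc1)C2` is one of three compounds measured in an assay on blood with Thromboxane-A synthase (Homo sapiens) as the target (on this read-out lower numbers stand for stronger inhibition and higher numbers for weaker inhibition), where compound 3 gives 2900 nM. It stands second highest of the three numbers: compound 2 `O=C(O)CCC/C=C\c1cc(Cc2cccnc2)cc2c1CCC(NS(=O)(=O)c1ccc(Cl)cc1)C2` gives 4200 nM, within the scatter of compound 3, while compound 1 `Cc1c(Cc2cccnc2)cc2c(c1CCC(=O)O)CCC(NS(=O)(=O)c1ccc(Cl)cc1)C2` gives 850 nM, beyond the scatter and the lowest of the set. Going by the values given here, the one single-point step available, a 3.4-fold higher number from compound 1 to compound 3 (0.53 log units; beyond the scatter), exchanges the whole side chain, which is not the change at hand. Compound 4 `Cc1c(Cc2cccnc2)cc2c(c1/C=C\CCCC(=O)O)CCC(NS(=O)(=O)c1ccc(Cl)cc1)C2` differs from compound 3 only in that (the two compounds have the same atoms and bonds; at least one stereo element is drawn with a configuration in one of them and without one in the other: 1 of 2 stereo elements differ; a double bond is drawn E in compound 3 and Z in compound 4). Among the compounds with values here, no measured step isolates this alteration of double-bond geometry. Compound 2, which carries a Z double bond in its own chain, shows a number within the scatter of compound 3, but its chain differs in other respects as well, so it does not settle the question. With nothing to point either way, the expected step is no change at the digits printed from compound 3 to compound 4 (within the scatter), not beyond the scatter. Compound 4 is therefore estimated at 2900 nM, with a range from 1200 nM to 7000 nM.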

Compound 4, half-maximal inhibitory concentration: 960 nM
Compound 4: the middle estimate sits 3.0-fold (0.48 log units) above what was measured, and the stated range ends above it.
By their numbers in this assay, from the lowest: compounds 1 and 4 (each within the scatter of the next); then compounds 3 and 2 (each within the scatter of the next).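

In this assay, the geometry of the double bond alone moves the number, a 3.0-fold lower number from compound 3 to compound 4 (0.48 log units; beyond the scatter), and the reading of this step rests on one point of the drawings: the fact that one of compounds 3 and 4 is drawn with a defined configuration and the other without, at the place where they differ. For the compounds shown here, with the Z double bond in place, the methyl on the aromatic carbon also shows a step of its own, a 4.4-fold lower number from compound 2 to compound 4 (0.64 log units; beyond the scatter), which the earlier compounds could not isolate because compound 2 had no partner differing in that one place. The longer chain in its Z form also stands level with the 2-carboxyethyl chain, a 1.1-fold higher number from compound 1 to compound 4 (0.05 log units; within the scatter), whereas the E form gave a step beyond the scatter from compound 1.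

The compounds shown leave open whether the methyl counts to the same degree when the double bond is E. They also leave open how a saturated 5-carboxypentyl chain, or a tetrazole in place of the carboxylic acid, would compare with compound 4.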